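The source may report more compounds than this note shows. Statements on the series, on what has been measured and on what is new or still open speak of the compounds shown alone.

Three lactones carrying two benzyl-type arms on the shared core were tested in a functional assay on HL-60 cells (Homo sapiens) for cytotoxicity, read by WST assay, with a stated time of 48 h; a higher number here means that more compound is needed for the effect, a lower number that less compound is needed. Compound 1 `Cc1cccc(C[C@H]2C(=O)OC[C@@H]2Cc2ccccc2)c1` gives 53000 nM. Compound 2 `O=C1OC[C@H](Cc2ccccc2)[C@H]1Cc1cccc(C(F)(F)F)c1` gives 34000 nM. Compound 3 `Cc1ccc(C[C@H]2C(=O)OC[C@@H]2Cc2ccccc2)cc1` gives 44000 nM. The move from compound 1 to compound 2 is trifluoromethyl in place of methyl on an aromatic carbon, and it made a step of a 1.6-fold lower number from compound 1 to compound 2 (0.19 log units; within the scatter). Compound 3 is related to compound 1 by 4-methylphenyl in place of 3-methylphenyl on a saturated chain carbon bound to a saturated ring carbon, which made a step of a 1.2-fold lower number from compound 1 to compound 3 (0.08 log units; within the scatter). All three values fall within the scatter of one another, so no order can be drawn among them.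

Compound 4 `O=C1OC[C@H](Cc2ccccc2)[C@H]1Cc1ccc(C(F)(F)F)cc1` has not been measured. It differs from compound 3 by trifluoromethyl in place of methyl on an aromatic carbon. Within the data shown here, this is the same kind of change as the one from compound 1 to compound 2, but not the same: in compound 2 the entering trifluoromethyl sits meta to a large group, whereas in compound 4 it sits para to a large group. Because the earlier change gave only a 1.6-fold lower number from compound 1 to compound 2 (0.19 log units; within the scatter), and because compound 3 itself gives 44000 nM, compound 4 is expected to show a step of about a 1.5-fold lower number from compound 3 to compound 4 (0.17 log units; within the scatter) in this assay, which lies within the scatter. Compound 4 is therefore estimated at 30000 nM, with a likely range from 15000 nM to 60000 nM.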

Compound 4, half-maximal effective concentration: 22000 nM
For compound 4 the middle estimate is 1.4-fold (0.13 log units) above the measured one; the measured number falls inside the stated range.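

In this assay, trifluoromethyl in place of methyl, on an aromatic carbon para to a large group, gives a 2.0-fold lower number from compound 3 to compound 4 (0.30 log units; within the scatter), and this step can be set beside the earlier one: the same change on two cores in this assay, a 1.6-fold lower number (0.19 log units; within the scatter) from compound 1 to compound 2 and a 2.0-fold lower number (0.30 log units; within the scatter) from compound 3 to compound 4, 1.3-fold (0.11 log units) apart, within the scatter of two such steps. The change therefore carries from one core to the other in this series without any difference that can be told between the two steps, and the two pairs read alike as far as the scatter allows. This does not show that the change itself moves the number, since each step on its own stays within the scatter, and two pairs cannot show that the position of the group on the ring has no bearing or that the same would hold on any other core.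

The compounds shown carry only methyl and trifluoromethyl on the substituted arm, so what a methoxy group, a chlorine atom, an amine or a carboxylic acid there would give stays open, as does any group on the unsubstituted phenyl ring of the other arm. Also open, going by these compounds, is whether the same swap would give a step beyond the scatter on a core with a longer chain joining the arm to the lactone.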